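The source may report more compounds than this note shows. Statements on the series, on what has been measured and on what is new or still open speak of the compounds shown alone.

In an assay on CHO cells for displacement of a labelled ligand from adenosine receptor A3 (Homo sapiens), read by scintillation counting, tested at 10 uM (a higher number here means more inhibition at the concentration tested (going by the name of the read-out), a lower number less inhibition), compound 1 `CC(C)(C)Cc1c(-c2ccncc2)sc(N)c1C(=O)c1ccc(Cl)cc1` gives 6%, and compound 2 `CC(C)(C)Cc1csc(N)c1C(=O)c1cccc(C(F)(F)F)c1` gives 1%; these two values lie within the usual scatter of each other, so neither compound stands apart from the other. Compound 3 `Cc1noc(C)c1-c1sc(N)c(C(=O)c2ccc(Cl)cc2)c1CC(C)(C)C` differs from compound 1 in one place: 3,5-dimethyl-1,2-oxazol-4-yl in place of pyridin-4-yl on an aromatic carbon. Within the data shown here, no measured pair shows what this change does in this assay. Both measured values are low. Accordingly, the step of a number 1 percentage points lower from compound 1 to compound 3 (within the scatter) is expected to be none beyond the scatter. Compound 3 is estimated to give 5% in this assay, with a likely range from 0% to 20%.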

Compound 3, a percentage reported as inhibition, at one concentration (the size of the read-out at that concentration, not a potency): 1%
The estimate for compound 3 lay 4 percentage points above the measured number; the range from low to high includes it.
By their numbers in this assay, from the lowest: compounds 2, 3 and 1 (each within the scatter of the next).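

In this assay, among these compounds, putting 3,5-dimethyl-1,2-oxazol-4-yl in place of pyridin-4-yl on the aromatic carbon next to the ring sulfur gives a number 5 percentage points lower from compound 1 to compound 3 (within the scatter) and so provides the first reading at this position. A five-membered aromatic ring and a six-membered one thus leave the number equally low here. No other measurement bears on this result.

From the compounds shown here alone, whether any group at this position can raise the number remains open, as both groups compared give low values. An amine or a carboxylic acid on this carbon could test that.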